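The compounds below may be only part of what the source reports. "The series", "measured", "known", "first", "only" and "open" are said of these compounds alone.

Measured compounds in a functional assay on HCT-116 cells (Homo sapiens) for inhibition, read by luminescence and resazurin assay, with a stated time of 3 days; on this read-out lower numbers stand for stronger inhibition and higher numbers for weaker inhibition:
compound 1 `CCNc1nc(NCc2ccc(NC(=O)c3ccc(F)cc3)cc2)c2ccccc2n1`: 1400 nM
compound 2 `CNc1nc(NCc2ccc(C(=O)Nc3ccc(F)cc3)cc2)c2ccccc2n1`: 2900 nM
compound 3 `CNc1nc(NCc2ccc(NC(=O)c3ccc(F)cc3)cc2)c2ccccc2n1`: 1600 nM

Compound 2 gives the highest of the three numbers in this assay. Its nearest neighbour is compound 3, reached through a 1.8-fold lower number from compound 2 to compound 3 (0.26 log units; within the scatter), a step that stays within the scatter. The gap to compound 1 is wider: the number for compound 1 sits beyond the scatter below that of compound 2, although no single-point change connects these two compounds directly.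

Compound 4 `CCNc1nc(NCc2ccc(C(=O)Nc3ccc(F)cc3)cc2)c2ccccc2n1` is not yet measured. It differs from compound 2 by methyl in place of hydrogen on a saturated chain carbon bound to a nitrogen on an aromatic ring; cut one bond further out, the change reads methyl to ethyl, methylamino to ethylamino. For the measured compounds named here, the only measured step that bears on this swap is the one between compound 1 and compound 3, run in the opposite direction: a 1.1-fold higher number from compound 1 to compound 3 (0.06 log units; within the scatter), which lies within the scatter. The same swap on the shared core therefore gives no reason to expect a step beyond the scatter in this assay, in either direction. The expected step is a 1.1-fold lower number from compound 2 to compound 4 (0.05 log units; within the scatter), within the scatter. Compound 4 is accordingly estimated at 2600 nM, with a range from 1300 nM to 5200 nM.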

Compound 4, half-maximal inhibitory concentration: 1900 nM
Beside the measured number, compound 4's estimate is 1.4-fold (0.14 log units) above it, within the range that was stated.
By their numbers in this assay, from the lowest: compounds 1, 3, 4 and 2 (each within the scatter of the next, the first and the last beyond it).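

Notes on the series: on the core of compound 2, methyl in place of hydrogen on a saturated chain carbon bound to a nitrogen on an aromatic ring now has a direct reading in this assay as a 1.5-fold lower number from compound 2 to compound 4 (0.18 log units; within the scatter) and stays within the scatter, so methylamino to ethylamino can be read on a second core and not only on the core of compound 1. The two forms of the amide also stay within the scatter with ethylamino in place, at a 1.4-fold higher number from compound 1 to compound 4 (0.13 log units; within the scatter) and this exchange now agrees with the one seen with methylamino: the same change on two cores in this assay, a 1.8-fold lower number (0.26 log units; within the scatter) from compound 2 to compound 3 and a 1.4-fold lower number (0.13 log units; within the scatter) from compound 4 to compound 1, 1.3-fold (0.13 log units) apart, within the scatter of two such steps. The chain change agrees in the same way, and at this position the shared core shows no dependence of one change on the other beyond the scatter: the same change on two cores in this assay, a 1.1-fold higher number (0.06 log units; within the scatter) from compound 1 to compound 3 and a 1.5-fold higher number (0.18 log units; within the scatter) from compound 4 to compound 2, 1.3-fold (0.13 log units) apart, within the scatter of two such steps.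

The compounds shown cover only methylamino and ethylamino at this position, so it stays open whether a longer chain such as propyl, or a chain ending in an amine, would give a step beyond the scatter. Also open, as far as these compounds go, is how a sulfonamide in place of either amide would read on this core.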